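Swapping chloro for methoxy on a sulfonamide nitrogen substituent

The compounds below may be only part of what the source reports. "The series", "measured", "known", "first", "only" and "open" are said of these compounds alone.

In a functional assay on DU-145 cells (Homo sapiens) for antiproliferative activity, read by sulforhodamine B assay, with a stated time of 48 h (on this read-out higher numbers stand for weaker inhibition and lower numbers for stronger inhibition), compound 1 (`Cc1cc(C)cc(NS(=O)(=O)c2ccc(N3CCNC3=O)cc2)c1`) gives 430 nM and compound 2 (`O=C1NCCN1c1ccc(S(=O)(=O)Nc2cccc(Cl)c2)cc1`) gives 230 nM, so these two compounds sit within the scatter of each other and cannot be ranked. Compound 3 (`COc1cccc(NS(=O)(=O)c2ccc(N3CCNC3=O)cc2)c1`) keeps the core of compound 2 and has methoxy in place of chloro on an aromatic carbon, (methoxy in place of chloro on an aromatic carbon). Going by the values given here, the one measured step that bears on this change, a 1.9-fold lower number from compound 1 to compound 2 (0.27 log units; within the scatter), put 3-chlorophenyl in place of 3,5-dimethylphenyl on a sulfonamide nitrogen and stayed within the scatter, so no shift beyond the scatter is expected in this assay. Among the compounds with values here, no measured compound carries methoxy, which leaves the expectation resting on little. The expected outcome is a 1.3-fold higher number from compound 2 to compound 3 (0.12 log units; within the scatter), inside the usual scatter. For compound 3 the estimated value is 300 nM, with a likely range of 120 nM to 750 nM.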

Compound 3, half-maximal inhibitory concentration: 650 nM
Beside the measured number, compound 3's estimate is 2.2-fold (0.34 log units) below it; the measured number falls inside the stated range.
By their numbers in this assay, from the lowest: compounds 2, 1 and 3 (each within the scatter of the next, the first and the last beyond it).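

In this assay, the step from chloro to methoxy on this ring carbon gives a 2.8-fold higher number from compound 2 to compound 3 (0.45 log units; beyond the scatter) and is the only step among these three compounds to clear the scatter, though modestly, so the choice of group at this place can register in the read-out. Going by these compounds alone, measured against the 3,5-dimethylphenyl of the first compound, the 3-methoxyphenyl gives a 1.5-fold higher number from compound 1 to compound 3 (0.18 log units; within the scatter) and so cannot be ranked against it, which means the 3-chlorophenyl of compound 2 and the 3-methoxyphenyl of compound 3 are the only pair here that separate. Nothing available here explains why these two groups part.

A single swap cannot show whether this gap would hold on another core or in another cell line. As far as these compounds go, how an amine, a carboxylic acid or a longer chain such as ethoxy would read on this same carbon remains open.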